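Replacing a ring methyl with a methoxy on the amide side chain

This account rests on a few compounds, and the source may have more. Where it says the series, first, only, none or still open, it means among the compounds named here.

Compound 1 `Cc1nc(NC(=O)C(C)(C)CC(F)(F)F)sc1-c1ccc(N)nc1` gives 3.4 in a physicochemical assay for lipophilicity, at pH 7.4; a lower number here means a more polar compound, a higher number a more lipophilic compound.
Compound 2 `Cc1nc(NC(=O)CN(Cc2ccccc2)C(=O)c2ccncc2)sc1-c1ccc(N)nc1` gives 2.8 in this assay.
Compound 3 `Cc1nc(NC(=O)C2(C)CCCCC2)sc1-c1ccc(N)nc1` gives 3.8 in this assay.

Compound 3 stands highest of the three in this assay; compound 1 sits nearest and compound 2 furthest below it. The step to compound 4 `CO[C@H]1CC[C@@H](C(=O)Nc2nc(C)c(-c3ccc(N)nc3)s2)CC1` is 4-methoxycyclohexyl in place of 1-methylcyclohexyl on a carbonyl carbon. Among the compounds with values here, only one measured step touches the same carbonyl carbon, and it went a number 0.40 log units higher from compound 1 to compound 3 (beyond the scatter); no measured pair exchanges a methyl for a methoxy, so that step gives no direct guide. Because compound 3 gives 3.8 and the change adds a hydrogen-bond acceptor while removing a methyl, a downward step a number 1.00 log units lower from compound 3 to compound 4 (beyond the scatter) is expected. Compound 4 is therefore estimated at 2.8, between 2.3 and 3.3.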

Compound 4, distribution coefficient: 2.8
Compound 4: middle estimate and measured number agree at the digits printed, within the range that was stated.
By their numbers in this assay, from the lowest: compounds 2 and 4 (each within the scatter of the next); then compound 1; then compound 3.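

Within the data shown here, at this position the only earlier step went upward, while 4-methoxycyclohexyl gives downward steps in this assay: a number 1.00 log units lower from compound 3 to compound 4 (beyond the scatter) and a number 0.60 log units lower from compound 1 to compound 4 (beyond the scatter). The number on this carbonyl carbon therefore moves in either direction, even with a six-membered ring of carbon only on both sides of the first step. Nothing available explains these steps. The compounds shown leave open how much of the drop belongs to the methoxy and how much to the lost methyl, as both change together. They also leave open what a hydroxyl or an amine on the same ring would give.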